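A few compounds are considered here, and "the series" means these few. Any claim that something is new, unique, unknown or untested is made for them only; others in the source may bear on it.

Compound 1 `CN(C)CCNc1ccnc2cc(OCc3ccc(F)cc3)ccc12` gives 580 nM in a functional assay on RKO cells (Homo sapiens) for cytotoxicity, read by MTT assay, with a stated time of 48 h; a higher number here means a weaker inhibitor, a lower number a stronger inhibitor.
Compound 2 `CC(C)COc1ccc2c(Cl)ccnc2c1` gives 2680 nM in this assay.
Compound 3 `CCCCOc1ccc2c(Cl)ccnc2c1` gives 3050 nM in this assay.

Among these three, compound 3 has the highest number, a weaker inhibitor than compound 1, while compound 2 and compound 3 lie within the scatter of each other. Compound 4 `CCCCCCCCOc1ccc2c(Cl)ccnc2c1` is compound 3 with one change: butyl in place of hydrogen on a saturated chain carbon, four bonds along the chain from an oxygen on an aromatic ring. Among the measured compounds shown here, no measured step extends a chain in this way. The only step shown, a 1.1-fold higher number from compound 2 to compound 3 (0.06 log units; within the scatter), swaps a branched chain for a straight one of the same size and changed nothing beyond the scatter; it suggests that the chain on the oxygen is tolerated in the forms tried, but it says nothing about a much longer chain. For the measured compounds named here, compound 1, the one compound with a markedly lower number, differs at several places at once, so it offers no guide here. Compound 4 is therefore expected to stay near compound 3, with the wide range reflecting the lack of a directly comparable step: the expected step is a 1.4-fold lower number from compound 3 to compound 4 (0.14 log units; within the scatter), and the estimate for compound 4 is 2200 nM, with a range of 600 nM to 8000 nM.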

Compound 4, half-maximal inhibitory concentration: 3640 nM
Compound 4: the middle estimate sits 1.7-fold (0.22 log units) below what was measured; measured number inside the range.
By their numbers in this assay, from the lowest: compound 1; then compounds 2, 3 and 4 (each within the scatter of the next).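

Adding butyl on a saturated chain carbon, four bonds along the chain from an oxygen on an aromatic ring, gives a 1.2-fold higher number from compound 3 to compound 4 (0.08 log units; within the scatter) in this assay. The earlier step only swapped a branched chain for a straight one of the same size, whereas this one adds 4 heavy atoms to the chain, and the number still moves no further than the scatter, so at this place the chain tolerates a large increase in length. No supporting measurement is available to explain this tolerance.

As far as these compounds go, whether a still longer chain, or a carboxylic acid or hydroxyl group on this chain, would shift the number remains open. The lower value of compound 1 also stays unexplained, since it differs from the others in several places at once.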